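This account rests on a few compounds, and the source may have more. Where it says the series, first, only, none or still open, it means among the compounds named here.

Compound 1 `O=S(=O)(/C=C/c1ccc(F)cc1)Cc1ccc(Nc2ncnc3ccccc23)cc1` and compound 2 `O=S(=O)(/C=C/c1ccc(Cl)cc1)Cc1ccc(Nc2ncnc3ccccc23)cc1` share one core and differ at a single aromatic carbon. In a functional assay on UACC-62 cells (Homo sapiens) (a lower number here means a stronger inhibitor of growth, a higher number a weaker inhibitor of growth), compound 1 gives 5000 nM, and compound 2 gives 13000 nM. The step of a 2.6-fold lower number from compound 2 to compound 1 (0.41 log units; beyond the scatter) comes from the change (fluoro in place of chloro on an aromatic carbon).

Compound 3 `O=S(=O)(/C=C/c1ccc(F)cc1Cl)Cc1ccc(Nc2ncnc3cc(Cl)ccc23)cc1` is built on a different core, and the difference between the two cores is not broken down here. In this assay compound 3 gives 72000 nM, the highest of the three numbers, and its gaps to compound 2 and to compound 1 both lie beyond the usual scatter.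

Compound 4 `O=S(=O)(/C=C/c1ccc(F)cc1F)Cc1ccc(Nc2ncnc3cc(Cl)ccc23)cc1` arises from compound 3 by the change (fluoro in place of chloro on an aromatic carbon). Among the compounds with values here, this is the same kind of change as the one from compound 2 to compound 1, but not the same: in compound 1 the new fluoro sits para to a large group, whereas in compound 4 it sits ortho to a large group and meta to a fluoro group.

Compound 4 is expected to give roughly 30000 nM in this assay, with a plausible range from 12000 nM to 80000 nM. The expected step is a 2.4-fold lower number from compound 3 to compound 4 (0.38 log units; beyond the scatter). This expectation rests on a single earlier instance, the step of a 2.6-fold lower number from compound 2 to compound 1 (0.41 log units; beyond the scatter), and the different surroundings of the exchanged atom make the size of the step less sure.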

Compound 4, concentration for 50% growth inhibition: > 100000 nM
Compound 4: only a limit was reported; the forecaster's own chance of this, stated with the estimate: 10%; middle value at least 3.3-fold (0.52 log units) away from the limit.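

In this assay compound 4 gives > 100000 nM, which is a limit of the assay and not a number, and it is the only such limit in this set: the limit of > 100000 nM in this assay, at which 1 of the 4 values shown sits.

That limit means the new step can be read only as a floor, an at least 1.3-fold higher number from compound 3 to compound 4 (0.14 log units; that floor lies within the scatter), yet the drop in number seen when fluoro replaced chloro on the core of compound 1 did not appear on the core of compound 3, and the two steps differ: the same change on two cores in this assay, a 2.6-fold lower number (0.41 log units; beyond the scatter) from compound 2 to compound 1 and an at least 1.3-fold higher number (0.14 log units; that floor lies within the scatter) from compound 3 to compound 4, at least 3.6-fold (0.55 log units) apart, beyond the scatter of two such steps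

Within the data shown here, this shows that, in this series, the size of the step seen on one core cannot simply be carried to another, but with only one pair on each core it gives no general rule, and it does not show how far beyond the limit compound 4 really lies, or whether the core itself or the different place of the exchanged atom on the ring accounts for the gap.

The compounds shown leave open what a methoxy group or a nitrile would do in place of the halogen on either core. Also open, as far as these compounds go, is what the core difference contributes by itself, for example whether replacing the chloro on the core of compound 3 with hydrogen or an amine would bring the fluoro step back.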